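Moving the fluorine on the aryl group: clearance notes

The source may report more compounds than this note shows. Statements on the series, on what has been measured and on what is new or still open speak of the compounds shown alone.

- compound 1 (`O=C(O)c1csc(-n2cc(-c3ccccc3)c3ccccc32)n1`) gives 2400 mL/min/kg as clearance
- compound 2 (`O=C(O)c1csc(-n2nc(-c3ccc(F)cc3)c3ccccc32)n1`) gives 278 mL/min/kg as clearance

Both values come from an ADME assay (liver) for metabolic stability, with Liver microsome (Rattus norvegicus) as the target, using microsomes (on this read-out lower numbers stand for slow clearance and higher numbers for fast clearance), and compound 2 holds the lowest of the two numbers, with compound 1 higher by a gap beyond the scatter. For the measured compounds named here, these two compounds differ in more than one place, so no single-change step is available to size the next move.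

Compound 3 (`O=C(O)c1csc(-n2nc(-c3cccc(F)c3)c3ccccc32)n1`) keeps the core of compound 2 and has 3-fluorophenyl in place of 4-fluorophenyl on an aromatic carbon. The two have the same atoms, joined differently. Going by the values given here, no measured pair shows this swap, so the expectation in this assay is for a small change, most likely not beyond the scatter. Among the compounds with values here, its direction is expected to be slightly upward, since compound 2 at 278 mL/min/kg is the lower of only two values. The expected step is a 1.2-fold higher number from compound 2 to compound 3 (0.09 log units; within the scatter) and this remains an estimate until measured. For compound 3 the expected clearance is 340 mL/min/kg with an estimated range from 150 mL/min/kg to 780 mL/min/kg as the working figure.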

Compound 3, clearance: 385 mL/min/kg
For compound 3 the middle estimate is 1.1-fold (0.05 log units) below the measured one; measured number inside the range.
By their numbers in this assay, from the lowest: compounds 2 and 3 (each within the scatter of the next); then compound 1.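

In this assay, for the compounds shown here, the swap of 3-fluorophenyl for 4-fluorophenyl on an aromatic carbon gives a 1.4-fold higher number from compound 2 to compound 3 (0.14 log units; within the scatter), and this is the first single-change step. On this read-out, the placement of the fluorine on the phenyl group does not separate the two compounds, which keep the same atoms joined differently, while compound 1 differs from each of them in more than one place and so gives no size for any single change. Nothing at hand bears on why the two values stand within the scatter of each other.

Still open, as far as these compounds go, is whether this position stays as flat for other groups, such as a chlorine, a methoxy group or a nitrile in place of the fluorine on the phenyl group. The shown compounds also leave open how clearance responds to changes elsewhere on the shared core, for instance an amide or a tetrazole in place of the carboxylic acid on the thiazole-bearing part.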